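Nitrile-chain series: cytotoxicity notes ahead of compound 3

The source may hold more compounds than are shown below. What is called first, only, known or untested is meant among the compounds shown, and "the series" means these compounds.

Measured so far:
compound 1, `Cc1nc2c(Br)c(Br)c(Br)c(Br)c2n1CC#N`: 45%
compound 2, `Cc1nc2c(Br)c(Br)c(Br)c(Br)c2n1CCCCC#N`: 92%

In a functional assay on CCRF-CEM cells (Homo sapiens) for cytotoxicity, read by MTT assay, with a stated time of 24 h, tested at 10 uM (on this read-out higher numbers stand for a weaker effect at the one concentration tested and lower numbers for a stronger effect), compound 1 gives 45%, and compound 2 gives 92%. Among the measured compounds shown here, the one step available, a number 47 percentage points higher from compound 1 to compound 2 (beyond the scatter), is the only comparison on record, so compound 2 stands with the higher of the two numbers, that is the weaker effect at the single concentration tested, and its nearest neighbour is compound 1.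

Compound 3, `N#CCCCCn1cnc2c(Br)c(Br)c(Br)c(Br)c21`, is the next compound to go into this assay. Relative to compound 2 it shows (hydrogen in place of methyl on an aromatic carbon). For the measured compounds named here, no measured pair in this set touches that methyl: the only step known, a number 47 percentage points higher from compound 1 to compound 2 (beyond the scatter), alters the chain on the ring nitrogen and says nothing about the carbon that loses its methyl here. With nothing to point either way, the expectation for compound 3 is a number close to that of compound 2, with no step beyond the scatter, estimated as a number 6 percentage points lower from compound 2 to compound 3 (within the scatter). The estimate for compound 3 in this assay is therefore 86%, expected to fall between 65% and 100%.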

Compound 3, a percentage reported as activity, at one concentration (the size of the read-out at that concentration, not a potency): 98%
Compound 3: middle estimate off by 12 percentage points, on the low side; the measured number falls inside the stated range.
By their numbers in this assay, from the lowest: compound 1; then compounds 2 and 3 (each within the scatter of the next).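

In this assay, among the compounds shown here, hydrogen in place of methyl on the aromatic carbon between two ring nitrogen atoms gives a number 6 percentage points higher from compound 2 to compound 3 (within the scatter), the first reading at this position, and with the 4-cyanobutyl group on the neighbouring ring atom the loss of the methyl leaves the number within the scatter. For the compounds shown here, the methyl therefore does not separate compound 2 from compound 3, and the chain step, a number 47 percentage points higher from compound 1 to compound 2 (beyond the scatter), remains the only step on record beyond the scatter. No supporting data bear on this result, so the flat reading at this carbon stands as an observation only.

The compounds shown leave open whether the methyl counts for as little alongside the shorter chain of compound 1, since the methyl has been exchanged only in the presence of the 4-cyanobutyl group. Also open, on these data alone, is whether a larger group on this aromatic carbon, such as an ethyl or an amine, would move the number, and whether a carboxylic acid in place of the nitrile at the chain end would do so.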